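The source may report more compounds than this note shows. Statements on the series, on what has been measured and on what is new or still open speak of the compounds shown alone.

In a functional assay on BGC-823 cells (Homo sapiens) for antiproliferative activity, read by sulforhodamine B assay, tested at 100 ug/mL (on this read-out higher numbers stand for more inhibition at the one concentration tested (going by the name of the read-out) and lower numbers for less inhibition), three compounds of one series have been examined so far. Compound 1, `Cc1ccc(NS(=O)(=O)C2CCCCC2=O)cc1`, gives 32.1% in this assay. Compound 2, `Cc1cccc(NS(=O)(=O)C2CCCCC2=O)c1C`, gives 24.5% in this assay, and compound 3, `O=C1CCCCCC1S(=O)(=O)c1ccc(Cl)c(Cl)c1`, gives 28.9% in this assay. Compound 1 thus holds the highest of the three numbers, but the gaps to compound 3 and to compound 2 both lie within the usual scatter of such measurements, so no order among the three can be read from these figures.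

Compound 4, `Cc1ccc(NS(=O)(=O)C2CCCCC2=O)c(C)c1`, has not yet been measured in this assay. It differs from compound 1 in one place: methyl in place of hydrogen on an aromatic carbon, ortho to the large group and meta to the methyl group already present. Within the data shown here, no step between two measured compounds in this set describes a change of this kind, so nothing measured points to a clear direction. The figures for compounds 1, 2 and 3 all sit close together, and a second methyl on the ring in compound 2 did not move the number beyond the scatter. He therefore expects a step of a number 4.1 percentage points lower from compound 1 to compound 4 (within the scatter) from compound 1 to compound 4, amounting to no change beyond the scatter. Compound 4 is estimated to give 28% in this assay, within a range from 17% to 40%.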

Compound 4, a percentage reported as inhibition, at one concentration (the size of the read-out at that concentration, not a potency): 15.6%
Beside the measured number, compound 4's estimate is 12.4 percentage points above it; measured number below the stated range.
By their numbers in this assay, from the lowest: compounds 4, 2, 3 and 1 (each within the scatter of the next, the first and the last beyond it).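

In this assay, methyl in place of hydrogen on an aromatic carbon, ortho to a large group and meta to a methyl group, gives a number 16.5 percentage points lower from compound 1 to compound 4 (beyond the scatter) and is the only step shown between two compounds that differ in one place. It shows that this aromatic carbon is not indifferent to substitution: a single methyl, with its 1 heavy atom, no ring and no net charge, is enough to lower the inhibition seen at the one concentration tested by more than repeated measurements would scatter. The compounds shown offer no measurement that explains why the number falls at this place.

The compounds shown leave open whether the fall belongs to methyl in particular or would follow any group on this aromatic carbon, such as a chlorine atom, a methoxy group or an amine. They also leave open whether the same change, made on the core of compound 3, would lower the number there, and whether a single step of this size at one concentration would carry over to a true measure of potency.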